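The source may report more compounds than this note shows. Statements on the series, on what has been measured and on what is new or still open speak of the compounds shown alone.

Of the compounds shown here, three on a shared core have been measured so far. In a functional assay on CRL2813 cells (Homo sapiens) for cytotoxicity, read by sulforhodamine B assay, with a stated time of 5 days (on this read-out lower numbers stand for stronger inhibition and higher numbers for weaker inhibition), compound 1 `O=C(Nc1cccc(C(=O)O)c1)N[C@H]1CC[C@H](Oc2ccc(F)cc2)CC1` gives only a limit, > 20000 nM. Compound 2 `Cc1ccccc1NC(=O)N[C@H]1CC[C@H](Oc2ccc(F)cc2)CC1` likewise gives only a limit in this assay, > 20000 nM. Compound 3 `O=C(Nc1cccc(Br)c1)N[C@H]1CC[C@H](Oc2ccc(F)cc2)CC1` gives 6200 nM in this assay. Compound 2 thus stands at the limit (the limit of > 20000 nM in this assay, at which 2 of the 3 values shown sit), with no number of its own. Compound 4 `O=C(Nc1ccccc1C(F)(F)F)N[C@H]1CC[C@H](Oc2ccc(F)cc2)CC1` differs from compound 2 by trifluoromethyl in place of methyl on an aromatic carbon. Within the data shown here, no measured step swaps methyl for trifluoromethyl; the steps of an at least 3.2-fold lower number from compound 2 to compound 3 (0.50 log units; beyond the scatter) and an at least 3.2-fold lower number from compound 1 to compound 3 (0.50 log units; beyond the scatter) show only that changing the group on the phenyl can bring the number down from the limit. A modest downward step an at least 1.3-fold lower number from compound 2 to compound 4 (0.12 log units; that floor lies within the scatter) is therefore expected, though a limit remains possible. Compound 4 is estimated at 15000 nM, between 5000 nM and 40000 nM.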

Compound 4, half-maximal inhibitory concentration: > 20000 nM
Compound 4: only a limit was reported (the forecaster's own chance of this, stated with the estimate: 45%); at least 1.3-fold (0.12 log units) between middle value and limit.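

No step can be read from compound 2 to compound 4, since both give only a limit: the limit of > 20000 nM in this assay, at which 3 of the 4 values shown sit. The compounds shown leave open how trifluoromethyl and methyl compare in this assay, where only compound 3 has a number.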